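A few compounds are considered here, and "the series" means these few. Any claim that something is new, unique, unknown or untested is made for them only; others in the source may bear on it.

Measured so far:
- compound 1, `O=C(c1ccc(Cl)cc1)N1CCC(NS(=O)(=O)c2cc(S(=O)(=O)c3ccccc3)ccc2C(F)(F)F)CC1`: 1800 nM
- compound 2, `CN(C)c1ccc(C(=O)N2CCC(NS(=O)(=O)c3cc(S(=O)(=O)c4ccccc4)ccc3C(F)(F)F)CC2)cn1`: 70 nM
- compound 3, `O=C(O)c1ccc(S(=O)(=O)N2CCC(NS(=O)(=O)c3cc(S(=O)(=O)c4ccccc4)ccc3C(F)(F)F)CC2)cc1`: 110 nM

All numbers come from an assay on U2OS cells for inhibition of secreted frizzled-related protein 1 (Homo sapiens), read by a luciferase reporter, with a stated time of 18 h; a higher number here means that more compound is needed for the effect, a lower number that less compound is needed. Compound 3 stands second highest of the three; compound 2 sits nearest, with a gap within the scatter, and compound 1 furthest, with a higher number by a margin beyond the scatter. Among the measured steps, the group on the amine nitrogen in the ring has proved decisive: a 26-fold lower number from compound 1 to compound 2 (1.41 log units; beyond the scatter) and a 16-fold lower number from compound 1 to compound 3 (1.21 log units; beyond the scatter) are both large, whereas a 1.6-fold higher number from compound 2 to compound 3 (0.20 log units; within the scatter) is within the scatter.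

Compound 4, `O=C(O)CCCC(=O)N1CCC(NS(=O)(=O)c2cc(S(=O)(=O)c3ccccc3)ccc2C(F)(F)F)CC1`, has not yet been measured in this assay. It differs from compound 3 by (3-carboxypropyl)carbonyl in place of (4-carboxyphenyl)sulfonyl on an amine nitrogen in a ring. For the measured compounds named here, the carboxylic acid is kept, but the six-membered aromatic ring leaves; no measured step tests a group without a ring at this position, so the two large steps show only that this position is sensitive, not which way the change will run. The working expectation for compound 4 in this assay is a moderate rise, a 5.5-fold higher number from compound 3 to compound 4 (0.74 log units; beyond the scatter), to an estimated 600 nM within a range from 150 nM to 3000 nM.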

Compound 4, half-maximal effective concentration: 570 nM
Estimate against measurement, compound 4: 1.1-fold (0.02 log units) above, and the stated range covers the measured number.
By their numbers in this assay, from the lowest: compounds 2 and 3 (each within the scatter of the next); then compound 4; then compound 1.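

In this assay, a group with no ring on the amine nitrogen in the ring can still lower the number relative to the 4-chlorophenyl amide, with a 3.2-fold lower number from compound 1 to compound 4 (0.50 log units; beyond the scatter) as the step. The ring-free acid does not match the two ring-bearing groups, however: a 5.2-fold higher number from compound 3 to compound 4 (0.71 log units; beyond the scatter) and an 8.1-fold higher number from compound 2 to compound 4 (0.91 log units; beyond the scatter) show that a carboxylic acid on this nitrogen does not by itself give the lowest numbers in the series. No measurement offered here gives a cause for these steps.

From the compounds shown here alone, the step between compound 3 and compound 4 changes the sulfonyl link, the aromatic ring and the chain together, so their separate shares stay open. A 4-carboxybenzoyl group would separate the link from the ring, and a longer chain ending in a carboxylic acid or an amine would test the chain and its end group.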